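From phenyl to 4-methoxyphenyl in compound 2

This account rests on a few compounds, and the source may have more. Where it says the series, first, only, none or still open, it means among the compounds named here.

Measured in a functional assay on MCF7 cells (Homo sapiens) for inhibition, read by sulforhodamine B assay, with a stated time of 48 h; on this read-out higher numbers stand for weaker inhibition and lower numbers for stronger inhibition:
- Compound 1 `CSc1nn(-c2ccccc2)c2ncnc(N/N=C/c3ccc(N)cc3)c12` gives 12 nM
- Compound 2 `CSc1nn(-c2ccccc2)c2ncnc(N/N=C/c3cccc(O)c3)c12` gives 10.7 nM
- Compound 3 `CSc1nn(-c2ccccc2)c2ncnc(N/N=C/c3ccc([N+](=O)[O-])cc3Cl)c12` gives 15.7 nM

Compound 2 cannot be ranked against the other two, since the gaps on either side (a 1.1-fold lower number from compound 1 to compound 2 (0.05 log units; within the scatter) and a 1.5-fold higher number from compound 2 to compound 3 (0.17 log units; within the scatter)) lie within the scatter. Compound 4 `COc1ccc(-n2nc(SC)c3c(N/N=C/c4cccc(O)c4)ncnc32)cc1` differs from it in one place (methoxy in place of hydrogen on an aromatic carbon): methoxy in place of hydrogen on an aromatic carbon, para to a large group, so that phenyl becomes 4-methoxyphenyl. Among the measured compounds shown here, no measured step touches that place. All three changed the ring on the carbon with a double bond to nitrogen, and the remaining one (a 1.3-fold higher number from compound 1 to compound 3 (0.12 log units; within the scatter)) also stayed within the scatter. These steps bear on the new change only indirectly, so the data give no direction for it, and no shift beyond the scatter is expected in this assay. The estimate means a small expected step (a 1.1-fold higher number from compound 2 to compound 4 (0.05 log units; within the scatter)) with a wide margin. Compound 4 is expected near 12 nM (estimated range 5 nM to 30 nM).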

Compound 4, half-maximal inhibitory concentration: 9.9 nM
Compound 4: middle estimate off by 1.2-fold (0.08 log units), on the high side, and the stated range covers the measured number.
By their numbers in this assay, from the lowest: compounds 4, 2, 1 and 3 (each within the scatter of the next).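

Compound 4 is the first shown with a change on the phenyl group rather than on the ring at the carbon with a double bond to nitrogen, and in this assay the step from phenyl to 4-methoxyphenyl stays within the scatter (a 1.1-fold lower number from compound 2 to compound 4 (0.03 log units; within the scatter)). So at this position, on an aromatic carbon para to a large group, methoxy and hydrogen give numbers that cannot be told apart in this assay. No measurement is available that could explain this result.

Going by these compounds, whether other groups at the same place would also stay within the scatter remains open, for example an amine, a carboxylic acid or a longer chain such as butoxy. One step also cannot show whether methoxy would read the same alongside the rings of compound 1 or compound 3.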